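This account rests on a few compounds, and the source may have more. Where it says the series, first, only, none or still open, it means among the compounds named here.

Measured in an ADME assay on Caco-2 cells (Homo sapiens) for permeability, read by LC-MS, with a stated time of 2 h, tested at 3 uM; on this read-out higher numbers stand for higher permeability and lower numbers for lower permeability:
compound 1 `CCN(c1cc2oc(-c3ccc(F)cc3)c(C(=O)NC)c2cc1-c1cc(F)c(OC)c(C(=O)NC2(c3ncccn3)CC2)c1)S(C)(=O)=O`: 406 nm/s
compound 2 `CCN(c1cc2oc(-c3ccc(F)cc3)c(C(=O)NC)c2cc1-c1cc(C)c(OC)c(C(=O)NC2(c3ncccn3)CC2)c1)S(C)(=O)=O`: 322 nm/s

Among the measured compounds shown here, compound 1 and compound 2 lie within the scatter of each other, so neither can be ranked above the other; the single measured step is a 1.3-fold lower number from compound 1 to compound 2 (0.10 log units; within the scatter). Compound 3 `CCN(c1cc2oc(-c3ccc(F)cc3)c(C(=O)NC)c2cc1-c1cc(F)c(F)c(C(=O)NC2(c3ncccn3)CC2)c1)S(C)(=O)=O` differs from compound 1 by fluoro in place of methoxy on an aromatic carbon. For the measured compounds named here, no measured step covers this change; the one measured step concerns a different group and stays within the scatter, which gives no ground to expect a move beyond the scatter in this assay. Compound 3 is therefore expected to give 450 nm/s in this assay, within 250 nm/s to 800 nm/s. The expected step is a 1.1-fold higher number from compound 1 to compound 3 (0.04 log units; within the scatter).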

Compound 3, apparent permeability: 623 nm/s
Estimate against measurement, compound 3: 1.4-fold (0.14 log units) below; measured number inside the range.
By their numbers in this assay, from the lowest: compounds 2, 1 and 3 (each within the scatter of the next).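

Fluoro in place of methoxy on this aromatic carbon, ortho to a (1-(pyrimidin-2-yl)cyclopropyl)carbamoyl group, gives a 1.5-fold higher number from compound 1 to compound 3 (0.19 log units; within the scatter) in this assay. At this position, a change that removes one hydrogen-bond acceptor and one heavy atom therefore stays within the scatter, whereas the earlier step concerned only the other substituent on the same ring. No measurement here gives a reason for this result. Going by these compounds, whether an amine or a carboxylic acid at this position would also stay within the scatter remains open.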